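This account rests on a few compounds, and the source may have more. Where it says the series, first, only, none or still open, it means among the compounds named here.

Two measured compounds frame this account. Compound 1 `COc1cc(Nc2nc3ccccc3nc2S(=O)(=O)c2ccc(C)cc2)cc(OC)c1` and compound 2 `COc1ccc(Nc2nc3ccccc3nc2S(=O)(=O)c2ccc(OC)cc2)cc1` share a core and differ in two places. In a functional assay on PC-3 cells (Homo sapiens) for cytotoxicity, read by MTT assay, with a stated time of 72 h (on this read-out lower numbers stand for stronger inhibition and higher numbers for weaker inhibition), compound 1 gives 2940 nM, and in this assay compound 2 gives 8710 nM, the highest of the two numbers; the gap between them lies beyond the scatter of repeated measurements.

Compound 3 `COc1ccc(S(=O)(=O)c2nc3ccccc3nc2Nc2cc(OC)cc(OC)c2)cc1` has not been measured in this assay. It departs from compound 2 by a single change: 3,5-dimethoxyphenyl in place of 4-methoxyphenyl on a nitrogen on an aromatic ring. With that change, compound 3 carries the same group on the nitrogen as compound 1, while keeping the group on the sulfonyl of compound 2.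

Within the data shown here, no step between two measured compounds matches this change on its own, so the expectation rests on where compound 1 and compound 2 stand. A lower number than that of compound 2 is expected for compound 3, because compound 1 gives 2940 nM with the 3,5-dimethoxyphenyl in place. The step expected from compound 2 to compound 3 is a 2.5-fold lower number from compound 2 to compound 3 (0.40 log units; beyond the scatter). The estimate for compound 3 is 3500 nM, within a range from 1500 nM to 8000 nM.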

Compound 3, half-maximal inhibitory concentration: 6220 nM
For compound 3 the middle estimate is 1.8-fold (0.25 log units) below the measured one; low and high end bracket the measured number.
By their numbers in this assay, from the lowest: compound 1; then compounds 3 and 2 (each within the scatter of the next).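

In this assay the change from 4-methoxyphenyl to 3,5-dimethoxyphenyl on a nitrogen on an aromatic ring gives a 1.4-fold lower number from compound 2 to compound 3 (0.15 log units; within the scatter) and so shows no clear effect of this change at this position when the methoxy group on the sulfonyl side is kept. Among these compounds, the other single change, methoxy in place of methyl on an aromatic carbon, gives a 2.1-fold higher number from compound 1 to compound 3 (0.33 log units; beyond the scatter) and, though modest, is the only one of the two steps that lies beyond the scatter. Nothing among the data shown gives a reason for either step.

As far as these compounds go, each change is read on a single pair, so it remains open whether the change on the nitrogen would also stay within the scatter with methyl rather than methoxy on the other side. The compounds shown also leave open how the number would respond if an amine, a carboxylic acid or a longer chain replaced the methoxy or methyl on that aromatic carbon, or if either replaced a methoxy group in the 3,5-dimethoxyphenyl.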